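This account rests on a few compounds, and the source may have more. Where it says the series, first, only, none or still open, it means among the compounds named here.

Measured so far in a functional assay on MDA-MB-231 cells (Homo sapiens) for inhibition, read by sulforhodamine B assay, tested at 10 uM; on this read-out lower numbers stand for less inhibition and higher numbers for more inhibition at the one concentration tested (going by the name of the read-out):
Compound 1 `CN1CCN(c2ccc(C3=NNC(c4ccc(N(C)C)cc4)C3)cc2)CC1` gives 11.4%.
Compound 2 `COC(=O)CC(=O)N1N=C(c2ccc(N3CCN(C)CC3)cc2)CC1c1ccc(N(C)C)cc1` gives -0.4%.
Compound 3 `CN1CCN(c2ccc(C3=NN(C(=O)c4ccc(C(F)(F)F)cc4)C(c4ccc(N(C)C)cc4)C3)cc2)CC1` gives 55.4%.

Compound 3 stands highest of the three, beyond the scatter of both others. Compound 4 `CN1CCN(c2ccc(C3=NN(S(C)(=O)=O)C(c4ccc(N(C)C)cc4)C3)cc2)CC1` differs from it in one place: methylsulfonyl in place of (4-(trifluoromethyl)phenyl)carbonyl on an amine nitrogen in a ring. Within the data shown here, two measured steps bear on this change. The step of a number 44 percentage points higher from compound 1 to compound 3 (beyond the scatter) shows that adding this large aryl carbonyl to the ring nitrogen lifted inhibition strongly, while a number 11.8 percentage points lower from compound 1 to compound 2 (beyond the scatter) shows that a small acyl group on the same nitrogen gave a modest drop. Methylsulfonyl is likewise a small group without a ring, so a large fall is expected, estimated as a number 43.4 percentage points lower from compound 3 to compound 4 (beyond the scatter). Compound 4 is therefore expected to give about 12%, within -5% to 35%.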

Compound 4, a percentage reported as inhibition, at one concentration (the size of the read-out at that concentration, not a potency): 0.6%
Beside the measured number, compound 4's estimate is 11.4 percentage points above it; low and high end bracket the measured number.
By their numbers in this assay, from the lowest: compounds 2 and 4 (each within the scatter of the next); then compound 1; then compound 3.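

On this ring nitrogen, methylsulfonyl does not keep the inhibition seen with (4-(trifluoromethyl)phenyl)carbonyl (a number 54.8 percentage points lower from compound 3 to compound 4 (beyond the scatter)). It matches the ((methoxycarbonyl)methyl)carbonyl group (a number 1 percentage points higher from compound 2 to compound 4 (within the scatter)) and falls short of the bare hydrogen (a number 10.8 percentage points lower from compound 1 to compound 4 (beyond the scatter)), so both ring-free groups sit low whether joined through sulfonyl or carbonyl, and only the aryl carbonyl stands high. No measurement here accounts for this. Going by these compounds, whether the benzene ring or its trifluoromethyl carries the rise remains open. A plain benzoyl or a phenylsulfonyl group on this nitrogen would begin to separate these.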